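The source may hold more compounds than are shown below. What is called first, only, known or untested is meant among the compounds shown, and "the series" means these compounds.

Compound 1, `Nc1ncnc2c1nc(NCCCCCCCCNC(=O)CI)n2[C@@H]1O[C@H](COP(=O)(O)OP(=O)(O)OP(=O)(O)O)[C@@H](O)[C@H]1O`: 0%
Compound 2, `O=C(CI)NCCCNc1ncnc2c1ncn2[C@@H]1O[C@H](COP(=O)(O)OP(=O)(O)OP(=O)(O)O)[C@@H](O)[C@H]1O`: 0%

Of the compounds shown here, two have so far been tested in an assay on isolated protein for inhibition of hexokinase-2 (Rattus norvegicus), with a stated time of 6 h, tested at 10 mM; a lower number here means less inhibition, a higher number more inhibition at the concentration tested (going by the name of the read-out). Compound 1 gives 0% in this assay, and compound 2 gives 0% in this assay. The two values are level at the digits reported: neither compound shows any inhibition at the concentration tested, and nothing separates them beyond the usual scatter. No single-change step between them is shown, so only the two numbers themselves can be set side by side.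

Compound 3, `O=C(CI)NCCCCCCCCNc1ncnc2c1ncn2[C@@H]1O[C@H](COP(=O)(O)OP(=O)(O)OP(=O)(O)O)[C@@H](O)[C@H]1O`, has not yet been measured. It differs from compound 2 in one place: 5-(((iodomethyl)carbonyl)amino)pentyl in place of ((iodomethyl)carbonyl)amino on a saturated chain carbon, three bonds along the chain from a nitrogen on an aromatic ring. The end group is kept, and the saturated chain that carries it becomes longer.

Because compound 2 gives 0% and compound 1 likewise gives 0%, a longer chain of this kind gives no reason to expect inhibition to appear. Compound 3 is therefore estimated to give 0%, with an expected range from 0% to 10%. The expected step is no change at the digits printed from compound 2 to compound 3 (within the scatter), that is, none beyond the scatter.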

Compound 3, a percentage reported as inhibition, at one concentration (the size of the read-out at that concentration, not a potency): 41%
The estimate for compound 3 lay 41 percentage points below the measured number; the whole stated range lies below it.
By their numbers in this assay, from the lowest: compounds 1 and 2 (each within the scatter of the next); then compound 3.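

In this assay, putting 5-(((iodomethyl)carbonyl)amino)pentyl in place of ((iodomethyl)carbonyl)amino on a saturated chain carbon, three bonds along the chain from a nitrogen on an aromatic ring, gives a number 41 percentage points higher from compound 2 to compound 3 (beyond the scatter). Within the data shown here, the end group is the same on both sides of this step and only the saturated chain carrying it grows, so this position is sensitive to chain length, something the two level values of the earlier compounds could not reveal. This read-out gives the size of the inhibition at one concentration and not a potency, and nothing measured here explains how the longer chain brings the inhibition about.

Among these compounds, what remains open is how the inhibition changes with chain length, since only two lengths at this position can be compared, and a shorter pentyl-type linker or a chain longer than that of compound 3 could sit anywhere relative to it. From the compounds shown here alone, it is also open whether the iodomethyl carbonyl end is needed on the longer chain, which a chloromethyl carbonyl group or a plain acetyl amide in its place would test.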